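From ethoxy to chloro on a level baseline

The source may report more compounds than this note shows. Statements on the series, on what has been measured and on what is new or still open speak of the compounds shown alone.

Of the compounds shown here, two with a shared core have so far been tested in a functional assay on B16-F10 cells (Mus musculus) for antiproliferative activity, read by MTT assay, with a stated time of 48 h; a higher number here means a weaker inhibitor, a lower number a stronger inhibitor. Here compound 1 `CCCC(C)Oc1ccc(C(=O)/C=C/c2c(/C=C/c3ccc(OC)cc3)cc(OC)cc2OC)cc1` gives 6.7 ug/mL, and compound 2 `CCOc1ccc(C(=O)/C=C/c2c(/C=C/c3ccc(OC)cc3)cc(OC)cc2OC)cc1` gives 6.4 ug/mL. Putting hydrogen in place of propyl on the saturated chain carbon bound to the oxygen gives a 1.0-fold lower number from compound 1 to compound 2 (0.02 log units; within the scatter), which lies within the scatter. Compound 2 therefore stands level with compound 1, and the numbers cannot rank the pair.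

Compound 3 `COc1ccc(/C=C/c2cc(OC)cc(OC)c2/C=C/C(=O)c2ccc(Cl)cc2)cc1` brings a larger structural change: chloro in place of ethoxy on an aromatic carbon. This is chloro in place of ethoxy on an aromatic carbon, para to a large group, turning the 4-ethoxyphenyl into a 4-chlorophenyl. For the measured compounds named here, only one measured step bears on it, and that step only indirectly. It altered the chain but kept the oxygen on the ring, whereas this change removes the oxygen too. Going by the values given here, no measured compound carries chloro, so the evidence is thin. Among the compounds with values here, with a 1.0-fold lower number from compound 1 to compound 2 (0.02 log units; within the scatter) as the only guide, no shift beyond the scatter is expected, and the estimated change is a 1.1-fold lower number from compound 2 to compound 3 (0.03 log units; within the scatter). For compound 3 the estimate in this assay is 6 ug/mL, with an expected range of 3 ug/mL to 12 ug/mL.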

Compound 3, half-maximal inhibitory concentration: 4.9 ug/mL
Beside the measured number, compound 3's estimate is 1.2-fold (0.09 log units) above it; low and high end bracket the measured number.
By their numbers in this assay, from the lowest: compounds 3, 2 and 1 (each within the scatter of the next).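

In this assay, the earlier pair varied only the chain attached to the oxygen, so it could not show whether that oxygen on the ring was needed at all. Compound 3 removes the oxygen along with the chain, yet replacing ethoxy with chloro gives a 1.3-fold lower number from compound 2 to compound 3 (0.12 log units; within the scatter) and stays within the scatter, so this ring position can lose its oxygen without a measurable shift in this assay. Replacing the bulkier 1-methylbutoxy with chloro gives a 1.4-fold lower number from compound 1 to compound 3 (0.14 log units; within the scatter) and is also within the scatter, which means that all three groups at this position, two with the oxygen and one without, leave the three numbers level, and no information is available to explain why.

From the compounds shown here alone, all three compounds carry either an alkoxy chain or chloro at this position, so it remains open whether a different kind of group, such as an amine, a hydroxyl or a carboxylic acid, would move the number beyond the scatter. Going by these compounds, it is equally open whether another halogen, such as fluoro or bromo, would stay level with chloro on the same shared core.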